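This account rests on a few compounds, and the source may have more. Where it says the series, first, only, none or still open, it means among the compounds named here.

Measured compounds in an in vitro assay on HEK-tsA201 cells for antagonist activity at Neuronal acetylcholine receptor; alpha4/beta2 (Homo sapiens), read by fluorescence and calcium flux; on this read-out lower numbers stand for stronger inhibition and higher numbers for weaker inhibition:
compound 1 `C=CCOc1ccc(C(=O)Nc2cccc(C)n2)cc1`: 6000 nM
compound 2 `C#CCOc1ccc(C(=O)Nc2cccc(C)n2)cc1`: 19400 nM
compound 3 `CCCCCNc1cccc(NC(=O)c2ccc(OCCC)cc2)n1`: > 100000 nM

Compound 3 gives only a limit in this assay, not a number, and so sits at the weak end of the values shown; the limit is the limit of > 100000 nM in this assay, at which 1 of the 3 values shown sits. Between the two numbered compounds the one measured step is a 3.2-fold higher number from compound 1 to compound 2 (0.51 log units; beyond the scatter).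

Compound 4 `CCCOc1ccc(C(=O)Nc2cccc(Nc3ccc(OC)cc3)n2)cc1` differs from compound 3 by 4-methoxyphenyl in place of pentyl on a nitrogen on an aromatic ring. Among the measured compounds shown here, the step from compound 1 to compound 2 changes the alkoxy chain on the benzamide side, not the substituent on the aromatic nitrogen, so it does not bear on this change; no measured step does. The expectation therefore rests on the limit of compound 3 alone. Compound 4 is estimated at 100000 nM, range 20000 nM to 500000 nM, the expected step being a number no higher from compound 3 to compound 4 (the limit leaves the size open), with a limit again the likely outcome.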

Compound 4, half-maximal inhibitory concentration: > 100000 nM
Compound 4: only a limit was reported (the forecaster's own chance of this, stated with the estimate: 60%); the middle value sits exactly at the limit.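

Compound 3 and compound 4 both stand only as limits, and the change from pentyl to 4-methoxyphenyl on the nitrogen cannot be read as a step. The compounds shown leave open which of these two groups gives the stronger inhibition.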